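The source may hold more compounds than are shown below. What is called first, only, known or untested is meant among the compounds shown, and "the series" means these compounds.

Compound 1 `OB1OCc2ccc(-n3cc(Sc4cccc(Cl)c4)c4ccccc43)cc21`: in an ADME assay on L929 cells (Mus musculus) for cytotoxicity, read by resazurin assay, with a stated time of 72 h (on this read-out lower numbers stand for stronger inhibition and higher numbers for weaker inhibition), compound 1 gives only the limit > 10 ug/mL.
Compound 2 `O=C(O)c1cccn1-c1ccc2c(c1)B(O)OC2`: compound 2 likewise gives only the limit > 10 ug/mL.
Compound 3 `CC(=O)c1ccn(-c2ccc3c(c2)B(O)OC3)c1`: compound 3 gives only the limit > 10 ug/mL.

None of the three measured compounds returns a number in this assay; all three sit at the limit of > 10 ug/mL in this assay, at which 3 of the 3 values shown sit. Compound 3 therefore stands level with the other two, with no numerical value that would set it apart. Compound 4 `NCCCC(=O)c1ccn(-c2ccc3c(c2)B(O)OC3)c1` differs from compound 3 by 2-aminoethyl in place of hydrogen on a saturated chain carbon bound to a carbonyl carbon. Within the data shown here, no measured pair carries this change, so no step size can be read from the data. Because the whole set of compounds 1, 2 and 3 rests at the limit of > 10 ug/mL in this assay, at which 3 of the 3 values shown sit, the step that the limit leaves unreadable from compound 3 to compound 4 is expected to be none beyond the scatter. Compound 4 is accordingly estimated at 20 ug/mL, with a range from 7 ug/mL to 60 ug/mL.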

Compound 4, half-maximal inhibitory concentration: > 10 ug/mL
Compound 4: a limit, no number; the forecaster's own chance of this, stated with the estimate: 75%; the middle value lies beyond the limit too.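

In this assay compound 4 gives > 10 ug/mL as a limit and not a number. Compound 3 also gives only a limit, so no step can be read between compound 3 and compound 4. The compounds shown leave open at what concentration any of them would reach half-maximal inhibition.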